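The source may report more compounds than this note shows. Statements on the series, on what has been measured and on what is new or still open speak of the compounds shown alone.

Measured so far:
compound 1 `Nc1n[nH]c2cc(-c3ccc(=O)n(Cc4ccccc4F)c3)ccc12`: 12 nM in an assay for inhibition of MAP kinase-interacting serine/threonine-protein kinase 1 (Homo sapiens), read by luminescence and ADP-Glo, with a stated time of 2 h; on this read-out lower numbers stand for stronger inhibition and higher numbers for weaker inhibition
compound 2 `O=C(N1CCOCC1)n1cc(-c2ccc3cn[nH]c3c2)ccc1=O`: > 2000 nM in this assay

Among the measured compounds shown here, compound 1 is the only entry with a number in this assay. Compound 2 reports no number, only (the limit of > 2000 nM in this assay, at which 1 of the 2 values shown sits). Compound 3 `Nc1n[nH]c2cc(-c3ccc(=O)n(Cc4cccc(F)c4)c3)ccc12` is not yet measured. It differs from compound 1 by 3-fluorophenyl in place of 2-fluorophenyl on a saturated chain carbon bound to an aromatic nitrogen. For the measured compounds named here, no measured step of this kind exists, so no size can be read off; the expected step of a 1.5-fold higher number from compound 1 to compound 3 (0.18 log units; within the scatter) is none beyond the scatter, with a slight lean towards weaker inhibition. Compound 3 is therefore estimated at 18 nM, within 5 nM to 70 nM.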

Compound 3, half-maximal inhibitory concentration: 19 nM
The estimate for compound 3 lay 1.1-fold (0.02 log units) below the measured number; the range from low to high includes it.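

In this assay, 3-fluorophenyl in place of 2-fluorophenyl on a saturated chain carbon bound to an aromatic nitrogen gives a 1.6-fold higher number from compound 1 to compound 3 (0.20 log units; within the scatter). Among the compounds shown here, this is the first measured step at this position, and it shows that the fluorine can sit in either of these two places on the phenyl ring with the difference staying within the scatter. No measured property shown bears on this result.

Still open, from the compounds shown here alone, is how this position responds to a larger change: a methoxy group, an amine or a carboxylic acid in place of the fluorine. Going by these compounds, a longer chain between the aromatic nitrogen and the phenyl ring is equally open.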